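A few compounds are considered here, and "the series" means these few. Any claim that something is new, unique, unknown or untested is made for them only; others in the source may bear on it.

Of the compounds shown here, three with a shared core have been tested in a functional assay on SF-268 cells (Homo sapiens) for inhibition, read by sulforhodamine B assay, with a stated time of 48 h; a lower number here means a stronger inhibitor of growth, a higher number a weaker inhibitor of growth. Compound 1 `O=C(Nc1cccc(-n2cc(-c3ccncc3)c(-c3ccc(Cl)c(O)c3)n2)c1)Nc1cccc(C(F)(F)F)c1` carries a urea linked to a 3-(trifluoromethyl)phenyl group and gives 1950 nM. Compound 2 `COc1cc(-c2nn(-c3cccc(NC(=O)c4cccc(C(F)(F)F)c4)c3)cc2-c2ccncc2)ccc1Cl` carries an amide in place of the urea, and in this assay compound 2 gives 2130 nM. Compound 3 `COc1cc(-c2nn(-c3cccc(NC(=O)Nc4ccc(Cl)c(Cl)c4)c3)cc2-c2ccncc2)ccc1Cl` returns to a urea, now bearing a (3,4-dichlorophenyl)amino group, and in this assay compound 3 gives 1510 nM. Going by the values given here, the one measured step, a 1.4-fold lower number from compound 2 to compound 3 (0.15 log units; within the scatter), is within the scatter, and all three numbers sit close together, so no one of them can be called stronger or weaker than the others.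

Compound 4 `COc1cc(-c2nn(-c3cccc(NC(=O)Nc4cccc(C(F)(F)F)c4)c3)cc2-c2ccncc2)ccc1Cl` is the next member: 3-(trifluoromethyl)phenyl in place of 3,4-dichlorophenyl on an amide-type nitrogen. This brings the urea of compound 4 to match the urea of compound 1, while the rest of compound 4 matches compound 3. Among the compounds with values here, the only step on record, from compound 2 to compound 3, was small, and compound 1 with the same urea as compound 4 sits near compound 3. The expectation is therefore a step of a 1.3-fold higher number from compound 3 to compound 4 (0.10 log units; within the scatter), which is within the scatter. Compound 4 is estimated at 1900 nM, with a range from 900 nM to 4000 nM.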

Compound 4, concentration for 50% growth inhibition: 1360 nM
Beside the measured number, compound 4's estimate is 1.4-fold (0.15 log units) above it, and the stated range covers the measured number.
By their numbers in this assay, from the lowest: compounds 4, 3, 1 and 2 (each within the scatter of the next).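

In this assay the change to 3-(trifluoromethyl)phenyl from 3,4-dichlorophenyl on the amide-type nitrogen gives a 1.1-fold lower number from compound 3 to compound 4 (0.05 log units; within the scatter) and so leaves the two groups indistinguishable at this position. Two other single changes read the same way: (3-(trifluoromethyl)phenyl)amino in place of 3-(trifluoromethyl)phenyl on a carbonyl carbon gives a 1.6-fold lower number from compound 2 to compound 4 (0.19 log units; within the scatter) and methyl in place of hydrogen on an oxygen on an aromatic ring gives a 1.4-fold lower number from compound 1 to compound 4 (0.16 log units; within the scatter), so among these four compounds none of the three changes separates one compound from another in growth inhibition. Why the numbers stay so close cannot be said, as no supporting information bears on this result.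

On these data alone, whether any group on this nitrogen can move the number beyond the scatter remains open, and a phenyl ring carrying a carboxylic acid or an amine, or a butyl chain in place of the ring, would test that. As far as these compounds go, the shared core is also constant across all four compounds, so what its parts contribute to growth inhibition is still unknown.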